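Replacing thiophen-2-yl with 2,6-dichlorophenyl on the sulfonyl sulfur

This account rests on a few compounds, and the source may have more. Where it says the series, first, only, none or still open, it means among the compounds named here.

In a functional assay on HeLa cells (Homo sapiens) for antiproliferative activity, read by MTT assay, with a stated time of 48 h (a higher number here means a weaker inhibitor, a lower number a stronger inhibitor), compound 1 (`Cn1cc(-c2cnc3ccnc(NS(=O)(=O)c4ccc(C(F)(F)F)cc4)c3c2)cn1`) reads > 50000 nM as a limit of the assay and not a number. Compound 2 (`Cc1ccc(S(=O)(=O)Nc2nccc3ncc(-c4cnn(C)c4)cc23)cc1`) reads > 50000 nM as a limit too. Among the measured compounds shown here, compound 3 (`Cn1cc(-c2cnc3ccnc(NS(=O)(=O)c4cccs4)c3c2)cn1`) gives 17400 nM as the only true number of the three, so it stands alone as the one measured value here.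

Compound 4 (`Cn1cc(-c2cnc3ccnc(NS(=O)(=O)c4c(Cl)cccc4Cl)c3c2)cn1`) is not yet measured and differs from compound 3 by 2,6-dichlorophenyl in place of thiophen-2-yl on a sulfonyl sulfur in one place: 2,6-dichlorophenyl in place of thiophen-2-yl on a sulfonyl sulfur. For the measured compounds named here, two measured steps bear on this, an at least 2.8-fold lower number from compound 1 to compound 3 (0.45 log units; beyond the scatter) and an at least 2.8-fold lower number from compound 2 to compound 3 (0.45 log units; beyond the scatter), and both are of at least modest size and beyond the scatter. The step that the two limits leave unreadable from compound 1 to compound 2 adds nothing readable. The new step runs the other way, from thiophen-2-yl back to a substituted phenyl, so a modest rise in the number is expected in this assay with the limit within reach. The expected step is a 1.8-fold higher number from compound 3 to compound 4 (0.26 log units; within the scatter) and no larger size can be read from these data. Compound 4 is estimated at 32000 nM within an expected range of 12000 nM to 50000 nM in this assay.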

Compound 4, half-maximal inhibitory concentration: > 50000 nM
Compound 4: a limit, no number; the forecaster's own chance of this, stated with the estimate: 40%; middle value at least 1.5-fold (0.19 log units) away from the limit.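

In this assay, compound 4 reads > 50000 nM, which is a limit of the assay and not a number. The change to 2,6-dichlorophenyl is an at least 2.8-fold higher number from compound 3 to compound 4 (0.45 log units; beyond the scatter), so a third substituted phenyl group on the sulfonyl sulfur joins the other two at the limit, and among the four compounds only thiophen-2-yl gives a true number, with none going against this. The steps from compound 1 and from compound 2 to compound 4 cannot be read, and the three phenyl groups cannot be ranked, because their values stop at the same point: the limit of > 50000 nM in this assay, at which 3 of the 4 values shown sit.

As far as these compounds go, what an unsubstituted phenyl, a furan ring or a short alkyl chain would do on the sulfonyl sulfur remains open. Also open, from the compounds shown here alone, is whether any group there can bring the number well below that of compound 3, 17400 nM.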